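A Fluoro-to-Chloro Change Tested for Clearance

The source may hold more compounds than are shown below. What is called first, only, known or untested is meant among the compounds shown, and "the series" means these compounds.

Of the compounds shown here, three sharing one core have been measured, each carrying a different aryl group on the sulfonyl sulfur. In an ADME assay on microsomes from liver (Homo sapiens) for metabolic stability, tested at 2.5 uM (on this read-out lower numbers stand for slow clearance and higher numbers for fast clearance), compound 1 `O=S(=O)(c1ccc(F)c(Cl)c1)c1cnc2cc(F)ccc2c1-c1cccc(F)c1` gives 0.25 mL/min. Compound 2 `COc1cccc(S(=O)(=O)c2cnc3cc(F)ccc3c2-c2cccc(F)c2)c1` gives 3.36 mL/min, and compound 3 `N#Cc1cccc(S(=O)(=O)c2cnc3cc(F)ccc3c2-c2cccc(F)c2)c1` gives 0.78 mL/min. The measured steps are a 13-fold higher number from compound 1 to compound 2 (1.13 log units; beyond the scatter), a 3.1-fold higher number from compound 1 to compound 3 (0.49 log units; beyond the scatter) and a 4.3-fold lower number from compound 2 to compound 3 (0.63 log units; beyond the scatter); compound 3 thus stands second highest of the three numbers, between compound 1 and compound 2.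

Compound 4 `N#Cc1cccc(S(=O)(=O)c2cnc3cc(F)ccc3c2-c2cccc(Cl)c2)c1` differs from compound 3 in one place: chloro in place of fluoro on an aromatic carbon. Among the compounds with values here, this change sits on a ring that none of the three measured steps touched, so no measured step bears on it directly; what is known is only that small changes on the sulfonyl aryl group moved the number in this assay by modest to large amounts. Within the data shown here, with no direct precedent, the change from compound 3 to compound 4 is expected to give a step of a 1.3-fold higher number from compound 3 to compound 4 (0.11 log units; within the scatter), not clearly beyond the scatter. The estimate for compound 4 in this assay is 1 mL/min, with a range from 0.4 mL/min to 2.5 mL/min.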

Compound 4, intrinsic clearance in a liver preparation (reported as CLH), per the amount of preparation that the assay uses: 0.99 mL/min
Beside the measured number, compound 4's estimate is 1.0-fold (0.00 log units) above it; the range from low to high includes it.
By their numbers in this assay, from the lowest: compound 1; then compounds 3 and 4 (each within the scatter of the next); then compound 2.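

In this assay, within the data shown here, the only measured change on this ring, 3-chlorophenyl in place of 3-fluorophenyl, gives a 1.3-fold higher number from compound 3 to compound 4 (0.10 log units; within the scatter). With the 3-cyanophenyl group held on the sulfonyl sulfur, this read-out therefore does not tell fluoro and chloro apart at this position, whereas all three steps among the different sulfonyl aryl groups lay beyond the scatter. Nothing at hand bears on what lies behind this result.

Going by these compounds, it remains open whether the same exchange would stay within the scatter with the 3-methoxyphenyl or the 3-chloro-4-fluorophenyl group on the sulfonyl sulfur. The compounds shown carry only halogens on this ring, so they also leave open how an amine, a carboxylic acid or a longer chain at this position would read in this assay.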